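Chloro for methoxy on a shared core

The compounds below may be only part of what the source reports. "The series", "measured", "known", "first", "only" and "open" are said of these compounds alone.

Compound 1 `Nc1nccc(COc2ccc3nc(N[C@@H]4CCCC[C@H]4O)sc3c2)c1Cl` gives 25 mL/min/kg
Compound 2 `COc1cc(OCc2ccnc(N)c2Cl)cc2sc(N[C@@H]3CCCC[C@H]3O)nc12` gives 38 mL/min/kg

Both compounds were measured in an ADME assay on microsomes from liver (Homo sapiens) for pharmacokinetics, read by LC-MS, using NADPH, with a stated time of 45 min, tested at 1 uM; on this read-out higher numbers stand for fast clearance and lower numbers for slow clearance. Among the compounds with values here, compound 2 is not clearly separated from compound 1, the only other measured compound, since the two values lie within the scatter of each other. The next compound, compound 3 `Nc1nccc(COc2cc(Cl)c3nc(N[C@@H]4CCCC[C@H]4O)sc3c2)c1Cl`, has chloro in place of methoxy on an aromatic carbon. Within the data shown here, no measured compound yet carries chloro at this aromatic carbon, so one step offers the only guide. That step, on the same carbon, is a 1.5-fold higher number from compound 1 to compound 2 (0.18 log units; within the scatter), and it shows that exchanging hydrogen for methoxy there made no difference beyond the scatter. On the strength of that step, no shift beyond the scatter is expected in this assay, in either direction. The expected step is a 1.3-fold lower number from compound 2 to compound 3 (0.10 log units; within the scatter). For compound 3 the estimated clearance is 30 mL/min/kg, with an expected range of 15 mL/min/kg to 58 mL/min/kg.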

Compound 3, clearance: 32 mL/min/kg
The estimate for compound 3 lay 1.1-fold (0.03 log units) below the measured number; the range from low to high includes it.
By their numbers in this assay, from the lowest: compounds 1, 3 and 2 (each within the scatter of the next).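

Replacing methoxy with chloro at this aromatic carbon gives a 1.2-fold lower number from compound 2 to compound 3 (0.07 log units; within the scatter) in this assay, and chloro in place of hydrogen gives a 1.3-fold higher number from compound 1 to compound 3 (0.11 log units; within the scatter). The earlier pair had set only hydrogen against methoxy, whereas hydrogen, methoxy and chloro at this carbon now all lie within the scatter of one another on this read-out, across compounds 1, 2 and 3. Nothing available here offers an explanation for this result.

As far as these compounds go, whether this holds for other groups at the same carbon stays open, as an amine, a carboxylic acid or a longer chain such as ethoxy could give a clearance beyond the scatter of these three. From the compounds shown here alone, it is also open whether the same result would hold with other parts of the shared core changed.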